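Configuration Change at the Chain Stereocentre, Compound 2 to 3

This account rests on a few compounds, and the source may have more. Where it says the series, first, only, none or still open, it means among the compounds named here.

Measured compounds:
compound 1 `C[C@H](Nc1nc(O)c2cc(Cl)ccc2n1)C1CCCCC1`: 2100 nM
compound 2 `C[C@@H](Nc1nc(O)c2cc(Cl)ccc2n1)c1ccccc1`: 2800 nM

In a functional assay (aorta) for inhibition, with Rattus norvegicus as the target (on this read-out lower numbers stand for stronger inhibition and higher numbers for weaker inhibition), compound 2 gives 2800 nM and stands at the top of the two numbers, while compound 1 gives 2100 nM, a gap that lies within the scatter. Compound 3 `C[C@H](Nc1nc(O)c2cc(Cl)ccc2n1)c1ccccc1` differs from compound 2 in this way: the two compounds have the same atoms and bonds and differ only in configuration as drawn: 1 of 1 stereo elements differ; a stereocentre at a saturated chain carbon is drawn R in compound 2 and S in compound 3. Among the compounds with values here, no measured pair shows this kind of change, so the expected step of a 1.1-fold higher number from compound 2 to compound 3 (0.03 log units; within the scatter) is set to none beyond the scatter, with a wide range to cover either direction. In this assay compound 3 is estimated at 3000 nM, between 600 nM and 15000 nM.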

Compound 3, half-maximal inhibitory concentration: 1700 nM
Compound 3: the middle estimate sits 1.8-fold (0.25 log units) above what was measured; the range from low to high includes it.
By their numbers in this assay, from the lowest: compounds 3, 1 and 2 (each within the scatter of the next).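

In this assay the chain stereocentre can now be read on its own: inverting it gives a 1.6-fold lower number from compound 2 to compound 3 (0.22 log units; within the scatter), so drawn R or S at this carbon makes no difference beyond the scatter. Phenyl in place of cyclohexyl gives a 1.2-fold lower number from compound 1 to compound 3 (0.09 log units; within the scatter), so that swap also stays within the scatter. The first step can be tied to configuration alone: the fact that compounds 2 and 3 differ only in the configuration as drawn

Open, as far as these compounds go, is whether a longer chain or an amine at this carbon, in place of phenyl or cyclohexyl, would move the number beyond the scatter. Also open, from the compounds shown here alone, is whether the two configurations would then still read alike.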